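Trading a Plain Phenyl for a Chloro-Fluoro Phenyl

This account rests on a few compounds, and the source may have more. Where it says the series, first, only, none or still open, it means among the compounds named here.

Three compounds have been measured in a functional assay for agonist activity at growth hormone secretagogue receptor type 1 (Homo sapiens), read by FLIPR; on this read-out lower numbers stand for smaller maximal responses and higher numbers for larger maximal responses:

Compound 1, `COc1ccc(NS(=O)(=O)c2ccc(-c3ccccn3)s2)cc1N1C[C@@H](C)N[C@@H](C)C1`, gives 0.9.
Compound 2, `CCOc1ccc(N2C[C@@H](C)N[C@@H](C)C2)cc1NS(=O)(=O)c1ccc(-c2ccccn2)s1`, gives 0.8.
Compound 3, `COc1ccc(N2C[C@@H](C)N[C@@H](C)C2)cc1NS(=O)(=O)c1ccc(-c2ccccc2)cc1`, gives 1.

Compound 3 carries the highest number of the three. The number for compound 1 sits close to it, within the usual scatter of repeated measurements, so the two cannot be told apart. The number for compound 2 lies further off, lower by more than the scatter, so compound 3 does stand apart from compound 2.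

Compound 4, `COc1ccc(N2C[C@@H](C)N[C@@H](C)C2)cc1NS(=O)(=O)c1ccc(-c2cc(Cl)ccc2F)cc1`, has not yet been measured. It differs from compound 3 in one place: 5-chloro-2-fluorophenyl in place of phenyl on an aromatic carbon. For the measured compounds named here, no pair among the measured compounds shows this kind of change, so there is no measured step to lean on. The three measured compounds all reach responses near the full response of the reference agonist, and the change here leaves the shared core untouched, so the expected step from compound 3 to compound 4 is small, a number 0.10 lower from compound 3 to compound 4 (within the scatter), most likely within the scatter and, if anything, downward. Compound 4 is therefore expected to give 0.9, with a range from 0.7 to 1.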

Compound 4, intrinsic activity: the largest response reached, as a fraction of the reference agonist's: 1
Compound 4: middle estimate off by 0.10, on the low side; the range from low to high includes it.
By their numbers in this assay, from the lowest: compounds 2, 1, 3 and 4 (each within the scatter of the next, the first and the last beyond it).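

In this assay, putting 5-chloro-2-fluorophenyl in place of phenyl, on an aromatic carbon para to a large group, gives no change at the digits printed from compound 3 to compound 4 (within the scatter) and leaves the shared core untouched. For the compounds shown here, this is the first direct look at this position, and it shows that the ring there can carry both a fluorine and a chlorine with the maximal response kept at the level of the reference agonist, which is what a fraction of one means on this scale. Nothing available here explains why the response holds, and this read-out, which records only the largest response reached, cannot tell how much of either compound is needed to reach it.

Still open, as far as these compounds go, is whether the response would hold with only the chlorine or only the fluorine on this ring. Also open, from the compounds shown here alone, is whether a group of a different kind at this position, such as a carboxylic acid or an aminomethyl group, would keep the response as well.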